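The source may report more compounds than this note shows. Statements on the series, on what has been measured and on what is new or still open speak of the compounds shown alone.

Compound 1 `FC(F)(F)c1cccc(NC(=S)Nc2cccc(Br)c2)c1` gives 14000 nM in an ADME assay on Vero 76 cells (Chlorocebus sabaeus) for cytotoxicity, read by crystal violet staining, with a stated time of 96 h; a higher number here means that more compound is tolerated, a lower number that less compound is tolerated.
Compound 2 `FC(F)(F)c1cccc(NC(=S)Nc2ccc(I)cc2)c1` gives 9500 nM in this assay.
Compound 3 `FC(F)(F)c1cccc(NC(=S)NCc2ccco2)c1` gives 50000 nM in this assay.

Compound 3 stands highest of the three numbers in this assay: the steps of a 3.6-fold higher number from compound 1 to compound 3 (0.55 log units; beyond the scatter) and a 5.3-fold higher number from compound 2 to compound 3 (0.72 log units; beyond the scatter) both run upward and beyond the scatter, so compound 3 is the best tolerated of the measured set. Between the two aryl compounds, a 1.5-fold lower number from compound 1 to compound 2 (0.17 log units; within the scatter) stays within the scatter, so exchanging 3-bromophenyl for 4-iodophenyl made little difference there.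

Compound 4 `FC(F)(F)c1cccc(NC(=S)Nc2ccccc2Br)c1` has not yet been measured. Its change from compound 3 is 2-bromophenyl in place of (furan-2-yl)methyl on an amide-type nitrogen. This reverses the kind of change seen in a 3.6-fold higher number from compound 1 to compound 3 (0.55 log units; beyond the scatter) and a 5.3-fold higher number from compound 2 to compound 3 (0.72 log units; beyond the scatter), where a (furan-2-yl)methyl group took the place of a halogen-bearing phenyl ring and the number rose. Since compound 4 again carries a bromine-bearing phenyl ring, a drop of about that size back toward the values of compound 1 and compound 2 is expected. Compound 4 is therefore expected to give about 15000 nM in this assay, with a likely range from 6000 nM to 40000 nM. From compound 3 the expected step is a 3.3-fold lower number from compound 3 to compound 4 (0.52 log units; beyond the scatter).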

Compound 4, half-maximal cytotoxic concentration: 50000 nM
Compound 4: middle estimate off by 3.3-fold (0.52 log units), on the low side; measured number outside the range, above it.
By their numbers in this assay, from the lowest: compounds 2 and 1 (each within the scatter of the next); then compounds 3 and 4 (each within the scatter of the next).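

The earlier compounds shown here suggested that a halogen-bearing phenyl ring on this amide-type nitrogen brings the number down, but no change at the digits printed from compound 3 to compound 4 (within the scatter) shows that this does not hold for every such ring in this assay. The placing of the bromine matters here: 2-bromophenyl in place of 3-bromophenyl gives a 3.6-fold higher number from compound 1 to compound 4 (0.55 log units; beyond the scatter), and the step from the 4-iodophenyl compound is of similar kind, a 5.3-fold higher number from compound 2 to compound 4 (0.72 log units; beyond the scatter), so the earlier pair of aryl compounds no longer speaks for aryl groups in general. No measurement shown here explains this difference between the two bromophenyl groups.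

As far as these compounds go, it remains open whether a 2-chlorophenyl or 2-iodophenyl group would behave like 2-bromophenyl. An unsubstituted phenyl ring or a 4-bromophenyl group would also help separate the effect of the halogen's identity from that of its place on the ring.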